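Methyl on the aromatic ring of compound 1: expected cytotoxicity

A few compounds are considered here, and "the series" means these few. Any claim that something is new, unique, unknown or untested is made for them only; others in the source may bear on it.

Compound 1 `O[C@@H]1Cc2ccccc2N[C@H](c2ccccc2)C1` is known in an ADME assay on THP-1 cells (Homo sapiens) for cytotoxicity, read by MTT assay, with a stated time of 72 h (on this read-out lower numbers stand for higher toxicity in this test and higher numbers for lower toxicity in this test), only through a limit. In this assay compound 1 gives > 300000 nM, which is a limit of the assay and not a number. Compound 3 `O[C@@H]1Cc2ccccc2N[C@H](c2ccc(F)cc2)C1`, carrying fluoro in place of hydrogen on an aromatic carbon, likewise sits at a limit: in this assay compound 3 gives > 300000 nM. Going by the values given here, compound 2 `O[C@@H]1Cc2cc(Br)ccc2N[C@H](c2ccccc2)C1`, with bromo in place of hydrogen on an aromatic carbon of the shared core, is the only one with a number: in this assay compound 2 gives 185000 nM. The step of an at least 1.6-fold lower number from compound 1 to compound 2 (0.20 log units; that floor lies within the scatter) thus remains within the scatter, and the step that the two limits leave unreadable from compound 1 to compound 3 is unreadable because of the limit of > 300000 nM in this assay, at which 2 of the 3 values shown sit.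

Compound 4 `Cc1cccc([C@@H]2C[C@H](O)Cc3ccccc3N2)c1` differs from compound 1 by methyl in place of hydrogen on an aromatic carbon. Both measured steps give no sign of a change beyond the scatter, so for compound 4 in this assay no step beyond the scatter is expected and a limit is the likelier outcome. The estimate for compound 4 in this assay is 250000 nM with a range of 100000 nM to 600000 nM. This corresponds to an expected step of an at least 1.2-fold lower number from compound 1 to compound 4 (0.07 log units; that floor lies within the scatter).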

Compound 4, half-maximal cytotoxic concentration: 176000 nM
Estimate against measurement, compound 4: 1.4-fold (0.15 log units) above, and the stated range covers the measured number.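

In this assay, methyl in place of hydrogen on an aromatic carbon, meta to a large group, gives a number rather than a limit, with an at least 1.7-fold lower number from compound 1 to compound 4 (0.23 log units; that floor lies within the scatter). Going by these compounds alone, this is the first number for a change on this six-membered aromatic ring of carbon only, but it shows no change beyond the scatter. How far the true step runs past that floor cannot be read, because compound 1 carries only a limit: the limit of > 300000 nM in this assay, at which 2 of the 4 values shown sit.

Going by these compounds, whether an amine, a carboxylic acid or a longer chain at this place would give a step beyond the scatter remains open. Also open, on these data alone, is how methyl would read at other places on this ring.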